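A few compounds are considered here, and "the series" means these few. Any claim that something is new, unique, unknown or untested is made for them only; others in the source may bear on it.

Of the compounds shown here, three of a shared core have been tested in a functional assay on HCT-116 cells (Homo sapiens) for inhibition, read by MTT assay, with a stated time of 48 h (a higher number here means a weaker inhibitor, a lower number a stronger inhibitor), and none of them gave a number. Compound 1 `COc1ccc(-n2c(SCC(=O)c3ccc(OC)c(O)c3)nnc2-c2cc(OC)c(OC)c(OC)c2)cc1` reaches only the limit of the assay, > 60000 nM. Compound 2 `COc1ccc(-n2c(SCC(=O)Nc3ccc(Cl)cc3)nnc2-c2cc(OC)c(OC)c(OC)c2)cc1` likewise stops at the limit, > 60000 nM. Compound 3 `COc1cc(-c2nnc(S)n2-c2ccc(N(C)C)cc2)cc(OC)c1OC`, which carries a free thiol on the core, also sits at the limit, > 60000 nM. Going by the values given here, the single change among the measured compounds, a step that the two limits leave unreadable from compound 1 to compound 2, cannot be read because both ends are limits, and that is the only measured step available.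

Compound 4 `COc1ccc(NC(=O)CSc2nnc(-c3cc(OC)c(OC)c(OC)c3)n2-c2ccc(N(C)C)cc2)cc1` grows out of compound 3 by ((4-methoxyphenyl)carbamoyl)methyl in place of hydrogen on a sulfur. Among the compounds with values here, the new group is much like the one compound 2 carries on its sulfur, so compound 2 is the closest measured neighbour of compound 4, and compound 2 also gave no number. With every measured value sitting at the limit (the limit of > 60000 nM in this assay, at which 3 of the 3 values shown sit), no direction for the step can be read from the data, and no change beyond the usual scatter is expected.

The step from compound 3 to compound 4 in this assay is therefore expected to be a number no higher from compound 3 to compound 4 (the limit leaves the size open). Compound 4 is estimated to give 60000 nM, between 20000 nM and 200000 nM, most likely again as a limit rather than a number.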

Compound 4, half-maximal inhibitory concentration: > 60000 nM
Compound 4: only a limit was reported; the forecaster's own chance of this, stated with the estimate: 70%; the middle value lies on the limit itself.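

No size or direction can be read for the step from compound 3 to compound 4, because both ends are limits and not numbers: the limit of > 60000 nM in this assay, at which 4 of the 4 values shown sit.

The compounds shown leave open whether any change on the shared core would give a real number in this assay, and which groups on the sulfur would matter.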